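A few compounds are considered here, and "the series" means these few. Any claim that something is new, unique, unknown or untested is made for them only; others in the source may bear on it.

Compound 1 `N#CC1=C(N)Oc2c(c3nc4ccccc4nc3c3ccccc23)C12C(=O)N(Cc1cnnn1-c1ccc(Cl)cc1)c1ccccc12` opens the series. In a functional assay on HCT-116 cells (Homo sapiens) for antiproliferative activity, read by MTT assay, with a stated time of 48 h (on this read-out higher numbers stand for weaker inhibition and lower numbers for stronger inhibition), compound 1 returns only the assay limit, > 50000 nM. Compound 2 `Cc1ccc(-n2nncc2CN2C(=O)C3(C(C#N)=C(N)Oc4c3c3nc5ccccc5nc3c3ccccc43)c3ccccc32)cc1C` differs by 3,4-dimethylphenyl in place of 4-chlorophenyl on an aromatic nitrogen. In this assay compound 2 likewise returns the limit, > 50000 nM. The step that the two limits leave unreadable from compound 1 to compound 2 is therefore unreadable. Compound 3 `Cc1ccccc1-n1nncc1CN1C(=O)C2(C(C#N)=C(N)Oc3c(N)cc4nc5ccccc5nc4c32)c2ccccc21` extends the set. In this assay compound 3 also stands at the limit, > 50000 nM. Going by the values given here, all three values sit at the limit of > 50000 nM in this assay, at which 3 of the 3 values shown sit, so no measured step has a readable size. Compound 4 `CCc1cccc(C)c1-n1nncc1CN1C(=O)C2(C(C#N)=C(N)Oc3c(N)cc4nc5ccccc5nc4c32)c2ccccc21` differs from compound 3 by ethyl in place of hydrogen on an aromatic carbon, 2-methylphenyl becoming 2-ethyl-6-methylphenyl. Among the compounds with values here, no measured step bears on this change. The estimated step of a number no higher from compound 3 to compound 4 (the limit leaves the size open) is expected to carry no readable direction. Compound 4 is expected to remain at the limit, with an estimate of 50000 nM within 20000 nM to 100000 nM.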

Compound 4, half-maximal inhibitory concentration: > 50000 nM
Compound 4 ended at the assay's limit; the forecaster's own chance of this, stated with the estimate: 85%; the middle value sits exactly at the limit.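

The step between compound 3 and compound 4 cannot be read, as both values are limits: the limit of > 50000 nM in this assay, at which 4 of the 4 values shown sit.

The compounds shown leave open whether any of these changes alters activity in this assay.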